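The source may report more compounds than this note shows. Statements on the series, on what has been measured and on what is new or still open speak of the compounds shown alone.

Compound 2 `CCn1c(=O)/c(=C2\Sc3cc(F)ccc3N2C)s/c1=C\c1ccncc1Nc1ccccc1C` carries a methyl on the aromatic carbon where compound 1 `CCn1c(=O)/c(=C2\Sc3cc(F)ccc3N2C)s/c1=C\c1ccncc1Nc1ccccc1F` carries a fluoro. In a functional assay on PC-3 cells (Homo sapiens) for inhibition (on this read-out higher numbers stand for weaker inhibition and lower numbers for stronger inhibition), compound 1 gives 260 nM, while compound 2 gives 2300 nM, which is the higher of the two numbers seen so far and therefore the weaker inhibition of the pair. Going by the values given here, the step that separates them, an 8.8-fold higher number from compound 1 to compound 2 (0.95 log units; beyond the scatter), is the only measured step that bears on the next compound.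

Compound 3 `CCn1c(=O)/c(=C2\Sc3cc(F)ccc3N2C)s/c1=C\c1ccncc1Nc1ccccc1Cl` is not yet measured. It differs from compound 2 in one place: chloro in place of methyl on an aromatic carbon. Chloro, like fluoro, is a halogen, yet it is closer in size to the methyl it replaces, so the change sits between the two measured compounds rather than at either end. Given that swapping fluoro for methyl produced the step from compound 1 to compound 2 of an 8.8-fold higher number from compound 1 to compound 2 (0.95 log units; beyond the scatter), a halogen returning at the same carbon is expected to move the number back part of the way, so the step from compound 2 to compound 3 is estimated at a 2.9-fold lower number from compound 2 to compound 3 (0.46 log units; beyond the scatter) in this assay. Compound 3 is accordingly expected to give about 800 nM, with a likely range from 250 nM to 2600 nM.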

Compound 3, half-maximal inhibitory concentration: 1200 nM
Estimate against measurement, compound 3: 1.5-fold (0.18 log units) below; low and high end bracket the measured number.
By their numbers in this assay, from the lowest: compound 1; then compounds 3 and 2 (each within the scatter of the next).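

In this assay, a 1.9-fold lower number from compound 2 to compound 3 (0.28 log units; within the scatter) stays within the usual scatter of repeated measurements, so chloro and methyl on this aromatic carbon cannot be told apart. By contrast, a 4.6-fold higher number from compound 1 to compound 3 (0.66 log units; beyond the scatter) lies beyond the scatter, which makes compound 1 the strongest inhibitor of the three and shows that a halogen at this carbon does not by itself bring back the lower number: among these three compounds, that number goes with fluoro alone, while chloro, also a halogen, reads like methyl. Nothing measured here offers an explanation for why fluoro stands apart from the other two groups.

The compounds shown leave open whether fluoro is the best choice at this carbon or simply the best of three, since a plain hydrogen, a methoxy group, a nitrile or an amine could land on either side of it. They also leave open whether the same ranking would hold with these groups placed elsewhere on the six-membered aromatic ring.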